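Swapping a Difluoromethoxy Group for Cyano on the Benzyl Arm

The source may hold more compounds than are shown below. What is called first, only, known or untested is meant among the compounds shown, and "the series" means these compounds.

Compounds measured so far:
- compound 1, `CCCCOc1ccc(CN(Cc2ccc(C(C)(C)C)cc2)Cc2cc3cc(C)ccc3[nH]c2=O)cc1`: > 5000 nM
- compound 2, `Cc1ccc2[nH]c(=O)c(CN(Cc3ccc(OC(F)F)cc3)Cc3ccc(C(C)(C)C)cc3)cc2c1`: > 5000 nM

Of the compounds shown here, two have been tested in a toxicity assay on MDCK cells (Canis lupus familiaris) for cytotoxicity, read by crystal violet staining, with a stated time of 48 h; a lower number here means that less compound is tolerated, a higher number that more compound is tolerated. Compound 1, with a butyl chain on the oxygen of one benzyl ring, gives only a limit in this assay, > 5000 nM, so no number is known for it. Compound 2 likewise gives only a limit in this assay, > 5000 nM. Going by the values given here, the one step between them, a step that the two limits leave unreadable from compound 1 to compound 2, therefore cannot be sized; all that is known is the limit of > 5000 nM in this assay, at which 2 of the 2 values shown sit.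

Compound 3, `Cc1ccc2[nH]c(=O)c(CN(Cc3ccc(C#N)cc3)Cc3ccc(C(C)(C)C)cc3)cc2c1`, is the next compound in this series. It differs from compound 2 in one place: cyano in place of difluoromethoxy on an aromatic carbon.

No measured step can be read in size, so there is no basis for expecting a shift in either direction. Among the compounds with values here, compound 2 sits at the limit, and the single change to compound 3 is small. Compound 3 is expected to sit at the same limit, an estimated 6000 nM with a range from 2500 nM to 20000 nM, meaning an expected step that the limit leaves unreadable from compound 2 to compound 3.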

Compound 3, half-maximal cytotoxic concentration: > 5000 nM
Compound 3 ended at the assay's limit; the forecaster's own chance of this, stated with the estimate: 80%; the middle value lies beyond the limit too.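

The steps from compound 2 to compound 3 and from compound 1 to compound 3 cannot be read in size, because each of these compounds gives only a limit and not a number: the limit of > 5000 nM in this assay, at which 3 of the 3 values shown sit.

The compounds shown leave open where the true half-maximal cytotoxic concentration of each lies, and whether cyano, difluoromethoxy or butoxy on the benzyl arm makes any difference to it.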